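The source may report more compounds than this note shows. Statements on the series, on what has been measured and on what is new or still open speak of the compounds shown alone.

Compound 3 `CCOC(=O)c1cnc(-c2csc(C)n2)nc1NN1C(=O)C=C(C)C1=O` gives 8000 nM in a functional assay on Jurkat cells for inhibition of nuclear factor NF-kappa-B complex (Homo sapiens) (a lower number here means a stronger inhibitor, a higher number a weaker inhibitor), the second highest of three numbers. Compound 1 `CCOC(=O)c1cnc(CC)nc1NN1C(=O)C=C(C)C1=O` gives 10000 nM, and a 1.3-fold lower number from compound 1 to compound 3 (0.10 log units; within the scatter), so these two cannot be told apart. Among the measured compounds shown here, compound 2 `CCOC(=O)c1cnc(-c2ccccc2)nc1NN1C(=O)C=C(C)C1=O` gives 100 nM, and an 80-fold higher number from compound 2 to compound 3 (1.90 log units; beyond the scatter), the one large step among the three. Compound 4 `CCOC(=O)c1cnc(-c2ccc(C)s2)nc1NN1C(=O)C=C(C)C1=O` is compound 3 with a single change: 5-methylthiophen-2-yl in place of 2-methyl-1,3-thiazol-4-yl on an aromatic carbon. For the measured compounds named here, only the step from compound 2 to compound 3 bears on this change, and it was large; the entering ring is a five-membered aromatic with one hetero atom, unlike either measured case. A lower number is therefore expected for compound 4, roughly a 5.3-fold lower number from compound 3 to compound 4 (0.73 log units; beyond the scatter), with considerable uncertainty. Compound 4 is estimated at 1500 nM, with a range from 200 nM to 8000 nM.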

Compound 4, half-maximal inhibitory concentration: 200 nM
The estimate for compound 4 lay 7.5-fold (0.88 log units) above the measured number; measured number inside the range.
By their numbers in this assay, from the lowest: compounds 2 and 4 (each within the scatter of the next); then compounds 3 and 1 (each within the scatter of the next).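

On the aromatic carbon between two ring nitrogen atoms, 5-methylthiophen-2-yl and 2-methyl-1,3-thiazol-4-yl give very different results in this assay (a 40-fold lower number from compound 3 to compound 4 (1.60 log units; beyond the scatter)), so a five-membered aromatic ring alone does not settle the outcome. The 5-methylthiophen-2-yl group also stands well apart from ethyl (a 50-fold lower number from compound 1 to compound 4 (1.70 log units; beyond the scatter)), yet it cannot be told apart from phenyl (a 2.0-fold higher number from compound 2 to compound 4 (0.30 log units; within the scatter)). Nothing available explains the gap between the two five-membered rings. From the compounds shown here alone, it remains open whether the ring nitrogen or the placement of the methyl decides the result, and how a phenyl ring carrying an amine would behave here.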